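A Small Group Swap at the High End

The source may report more compounds than this note shows. Statements on the series, on what has been measured and on what is new or still open speak of the compounds shown alone.

Three related compounds have been measured in a functional assay on VCaP cells (Homo sapiens) for antiproliferative activity, read by fluorescence and propidium iodide staining, with a stated time of 96 h; a lower number here means a stronger inhibitor, a higher number a weaker inhibitor. Compound 1 (`CC(O)(CSc1cc(C(F)(F)F)cc(C(F)(F)F)c1)C(=O)Nc1ccc([N+](=O)[O-])cc1C(F)(F)F`) gives 3520 nM. Compound 2 (`CC(O)(CSc1cc(C(F)(F)F)cc(C(F)(F)F)c1)C(=O)Nc1ccc(C(F)(F)F)cc1`) gives 9880 nM. Going by the values given here, compound 3 (`CC(O)(CSc1cccc(C(F)(F)F)c1)C(=O)Nc1cc(C(F)(F)F)cc(C(F)(F)F)c1`) gives 9860 nM, and this value lies within the usual scatter of the one for compound 2, so the two cannot be told apart. Compound 1 has a lower number than compound 3, by more than the scatter, which leaves compound 3 alongside compound 2 on the high side of this small set.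

The next compound is compound 4 (`CC(O)(CSc1cccc(OC(F)(F)F)c1)C(=O)Nc1cc(C(F)(F)F)cc(C(F)(F)F)c1`). It keeps all of compound 3 except for one group, with trifluoromethoxy in place of trifluoromethyl on an aromatic carbon. Among the compounds with values here, no two measured compounds differ in just one place, so the data offer no direct guide to the size of this step. The expectation therefore starts from compound 3, at 9860 nM, and no step beyond the scatter is expected in this assay, in either direction. The expected change is a 1.2-fold lower number from compound 3 to compound 4 (0.09 log units; within the scatter). The estimated value for compound 4 is 8000 nM, with an expected range of 3500 nM to 18000 nM.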

Compound 4, half-maximal inhibitory concentration: 9290 nM
The estimate for compound 4 lay 1.2-fold (0.06 log units) below the measured number; measured number inside the range.
By their numbers in this assay, from the lowest: compound 1; then compounds 4, 3 and 2 (each within the scatter of the next).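

Going by these compounds alone, compound 3 and compound 4 form the first measured pair that differs in only one place, so the size of a single change can now be read directly in this assay: the step is a 1.1-fold lower number from compound 3 to compound 4 (0.03 log units; within the scatter). At this position, on an aromatic carbon meta to a large group, trifluoromethoxy and trifluoromethyl therefore cannot be told apart in this assay, even though trifluoromethoxy counts one more heavy atom and one hydrogen-bond acceptor. Nothing measured here says why the two groups give such similar results.

This single pair leaves open whether other groups at the same position, such as an amine, a nitrile, a carboxylic acid or a longer alkoxy chain, would also stay within the scatter or would move the number beyond it, and whether the same swap would behave alike on a different core. Within the data shown here, no single-place step yet connects compound 1 or compound 2 to the other compounds, so which structural feature goes with the lower number of compound 1, 3520 nM, also remains unresolved.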